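The compounds below may be only part of what the source reports. "The series", "measured", "known", "first", "only" and "open" are said of these compounds alone.

- Compound 1 `CNC(=O)c1cc(Oc2ccc(C(=O)/C=C/c3ccc(Cl)c(Cl)c3)cc2)ccn1`: 33700 nM
- Compound 2 `CNC(=O)c1cc(Oc2ccc(C(=O)/C=C/c3ccc(F)cc3Cl)cc2)ccn1`: 21100 nM

In a functional assay on A549 cells (Homo sapiens) for cytotoxicity, read by MTT assay, with a stated time of 72 h (a lower number here means a stronger inhibitor, a higher number a weaker inhibitor), compound 2 gives 21100 nM and stands within the scatter of compound 1, which gives 33700 nM. Compound 3 `CNC(=O)c1cc(Oc2ccc(C(=O)/C=C/c3ccccc3)cc2)ccn1` differs from compound 2 by phenyl in place of 2-chloro-4-fluorophenyl on a double-bonded chain carbon bound to a double-bonded chain carbon: phenyl in place of 2-chloro-4-fluorophenyl. Within the data shown here, the one measured step at this place, a 1.6-fold lower number from compound 1 to compound 2 (0.20 log units; within the scatter), stays within the scatter. Among the measured compounds shown here, no measured compound carries the plain phenyl, so no step beyond the scatter is expected in this assay. The expected change is a 1.4-fold higher number from compound 2 to compound 3 (0.15 log units; within the scatter). Compound 3 is estimated at 30000 nM, with an expected range of 12000 nM to 70000 nM.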

Compound 3, half-maximal inhibitory concentration: 5040 nM
Estimate against measurement, compound 3: 6.0-fold (0.77 log units) above; the whole stated range lies above it.
By their numbers in this assay, from the lowest: compound 3; then compounds 2 and 1 (each within the scatter of the next).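

In this assay the plain phenyl gives what the two halogenated compounds did not give between them, a step beyond the scatter at this place: a 4.2-fold lower number from compound 2 to compound 3 (0.62 log units; beyond the scatter) and a 6.7-fold lower number from compound 1 to compound 3 (0.83 log units; beyond the scatter). Both 2-chloro-4-fluorophenyl and 3,4-dichlorophenyl therefore give higher numbers than phenyl on a double-bonded chain carbon bound to a double-bonded chain carbon. Nothing available explains this difference. The compounds shown leave open whether a lone fluorine, a methoxy group or an amine on the phenyl would keep the lower number.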